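Swapping a Neopentylamino Group for Azetidine at the Benzylic Site

A few compounds are considered here, and "the series" means these few. Any claim that something is new, unique, unknown or untested is made for them only; others in the source may bear on it.

Measured compounds:
compound 1 `CC(C)(C)NCc1ccc2c(c1)CCC[C@H]2NC(=O)C[C@@H]1CCCCN1S(=O)(=O)c1ccccc1` — 1700 nM
compound 2 `CC(C)(C)CNCc1ccc2c(c1)CCC[C@H]2NC(=O)C[C@@H]1CCCCN1S(=O)(=O)c1cccc(C(F)(F)F)c1` — 59 nM

Both compounds were tested in an assay on isolated protein for inhibition of B1 bradykinin receptor (Homo sapiens); a lower number here means a stronger inhibitor, a higher number a weaker inhibitor. Compound 1 gives 1700 nM, while compound 2 gives 59 nM, so compound 2 holds the lower of the two numbers, and the gap between them is beyond the usual scatter. The two compounds differ in more than one place, so the gap cannot be tied to a single change.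

Compound 3 `O=C(C[C@@H]1CCCCN1S(=O)(=O)c1cccc(C(F)(F)F)c1)N[C@@H]1CCCc2cc(CN3CCC3)ccc21` has not yet been measured. It is built from compound 2 by one change: azetidin-1-yl in place of neopentylamino on a saturated chain carbon bound to an aromatic carbon. In plain words, a branched open-chain amine is replaced by a small saturated ring amine, and the hydrogen-bond donor at that spot is lost, while one acceptor remains.

Going by the values given here, no measured pair shows the effect of this particular change on this assay. Compound 3 is expected to sit close to compound 2, with a modest move toward a higher number, and the step from compound 2 to compound 3 is estimated as a 2.0-fold higher number from compound 2 to compound 3 (0.31 log units; beyond the scatter). Compound 3 is expected to give 120 nM, within a range of 35 nM to 450 nM.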

Compound 3, half-maximal inhibitory concentration: 1100 nM
The estimate for compound 3 lay 9.2-fold (0.96 log units) below the measured number; the measured number lies above the stated range.
By their numbers in this assay, from the lowest: compound 2; then compounds 3 and 1 (each within the scatter of the next).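

In this assay, replacing neopentylamino with azetidin-1-yl on a saturated chain carbon bound to an aromatic carbon gives a 19-fold higher number from compound 2 to compound 3 (1.27 log units; beyond the scatter) with everything else held constant. Going by these compounds alone, this is the first reading of this position on its own, since compound 1 and compound 2 differ in more than one place, and it shows that the result is highly sensitive to the amine at this site: the large step comes from this one change. The swap alters several features at once, removing the hydrogen-bond donor, shortening the group and replacing an open chain with a four-membered ring, and nothing shown here establishes which of these matters.

Still open is which feature accounts for the step: cyclobutylamino would keep the hydrogen-bond donor alongside a four-membered ring, while pyrrolidin-1-yl would test a larger ring without that donor. From the compounds shown here alone, it is also open whether the same swap would have a comparable effect without the trifluoromethyl group, the form of the sulfonyl-bound ring seen in compound 1.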